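Moving a Hydroxyl Group Before the Fourth Compound Is Measured

The source may report more compounds than this note shows. Statements on the series, on what has been measured and on what is new or still open speak of the compounds shown alone.

Compound 1 `Oc1cccc(-c2cc(-c3ccccn3)cc(-c3ccccc3O)n2)c1` carries a 3-hydroxyphenyl group on the shared core. In a functional assay on HCT-15 cells (Homo sapiens) for cytotoxicity, read by CCK-8 assay (a lower number here means a stronger inhibitor, a higher number a weaker inhibitor), compound 1 gives > 50000 nM, which is a limit of the assay rather than a number. Compound 2 `Oc1ccc(-c2cc(-c3ccccn3)cc(-c3ccccc3O)n2)cc1` differs from compound 1 by 4-hydroxyphenyl in place of 3-hydroxyphenyl on an aromatic carbon. In this assay compound 2 gives > 50000 nM, again a limit and not a number. The measured step is therefore a step that the two limits leave unreadable from compound 1 to compound 2. Compound 3 `Oc1cccc(-c2cc(-c3cccnc3)cc(-c3cccc(O)c3)n2)c1` has a different core from compound 1; the difference between the two cores is not broken down here. In this assay compound 3 gives > 50000 nM, also a limit of the assay. All three measured values sit at one point, as the limit of > 50000 nM in this assay, at which 3 of the 3 values shown sit, shows.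

Compound 4 `Oc1ccc(-c2cc(-c3cccnc3)cc(-c3cccc(O)c3)n2)cc1` is not yet measured and differs from compound 3 by 4-hydroxyphenyl in place of 3-hydroxyphenyl on an aromatic carbon. This is the same kind of change as that from compound 1 to compound 2, though the surroundings differ: in compound 3 the place is meta to a 3-hydroxyphenyl group and meta to a pyridin-3-yl group, whereas in compound 1 it is meta to a 2-hydroxyphenyl group and meta to a pyridin-2-yl group. Because the limit of > 50000 nM in this assay, at which 3 of the 3 values shown sit, places all three measured compounds at the limit, and the earlier step that the two limits leave unreadable from compound 1 to compound 2 could not be read, the step expected in this assay is a number no higher from compound 3 to compound 4 (the limit leaves the size open). Compound 4 is expected to give about 50000 nM in this assay, most likely once more as a limit, within an estimated range of 20000 nM to 150000 nM.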

Compound 4, half-maximal inhibitory concentration: > 50000 nM
Compound 4 ended at the assay's limit (the forecaster's own chance of this, stated with the estimate: 85%); the middle value lies on the limit itself.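

Like compound 3, compound 4 stands at a limit of the assay and not at a number, so the step between compound 3 and compound 4 cannot be read. The compounds shown leave open whether moving the hydroxyl group changes the activity in this assay at all, and which change to these structures would give a readable number, since all of them sit at one point: the limit of > 50000 nM in this assay, at which 4 of the 4 values shown sit.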